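Lactam in place of succinimide on the piperidine nitrogen substituent

This account rests on a few compounds, and the source may have more. Where it says the series, first, only, none or still open, it means among the compounds named here.

Compound 2 `Cc1nc(N2CCC(N3C(=O)CCC3=O)CC2)nc2ccc(NC(=O)/C=C/c3ccc(OC(F)(F)F)cc3)cc12` stands at the higher end of the two numbers recorded so far: in an assay on CHO-K1 cells for displacement of a labelled ligand from melanin-concentrating hormone receptor 1 (Homo sapiens), read by scintillation proximity assay, with a stated time of 2 h (a lower number here means a stronger inhibitor, a higher number a weaker inhibitor), compound 2 gives 94 nM, whereas compound 1 `Cc1nc(N2CCC(N3CCCS3(=O)=O)CC2)nc2ccc(NC(=O)/C=C/c3ccc(OC(F)(F)F)cc3)cc12` gives 4 nM. For the measured compounds named here, the one measured step is a 24-fold higher number from compound 1 to compound 2 (1.37 log units; beyond the scatter). Compound 3 `Cc1nc(N2CCC(N3CCCC3=O)CC2)nc2ccc(NC(=O)/C=C/c3ccc(OC(F)(F)F)cc3)cc12` carries 2-oxopyrrolidin-1-yl in place of 2,5-dioxopyrrolidin-1-yl on a saturated ring carbon. Going by the values given here, no measured step matches this change; the only step available shows that the substituent on this saturated ring carbon matters strongly. A step of moderate size toward a lower number is therefore expected, a 2.4-fold lower number from compound 2 to compound 3 (0.37 log units; beyond the scatter). Compound 3 is estimated at 40 nM, within the range 10 nM to 150 nM.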

Compound 3, half-maximal inhibitory concentration: 11 nM
Estimate against measurement, compound 3: 3.6-fold (0.56 log units) above; low and high end bracket the measured number.
By their numbers in this assay, from the lowest: compound 1; then compound 3; then compound 2.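

Going from 2,5-dioxopyrrolidin-1-yl to 2-oxopyrrolidin-1-yl gives an 8.5-fold lower number from compound 2 to compound 3 (0.93 log units; beyond the scatter) on a saturated ring carbon, so the number responds to a change within the five-membered ring itself, not only to replacing the whole group. The lactam recovers only part of the gap to the sulfur-containing ring, with a 2.8-fold higher number from compound 1 to compound 3 (0.44 log units; beyond the scatter) remaining between them. No available data explain either step.
Still open, going by these compounds, is whether a plain pyrrolidin-1-yl amine, with no carbonyl on the ring, or an open-chain acetamide at this carbon would lower the number further.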